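The source may hold more compounds than are shown below. What is called first, only, known or untested is meant among the compounds shown, and "the series" means these compounds.

Working notes on the series. Going by the values given here, in a functional assay on MCF7 cells (Homo sapiens) for inhibition, read by sulforhodamine B assay, with a stated time of 48 h, tested at 50 uM (a lower number here means less inhibition of growth, a higher number more inhibition of growth at the concentration tested), compound 1 (`COc1ccc([C@@H]2C/C(=N/OCc3cn(-c4ccc(C#N)cc4)nn3)c3cc(CC=C(C)C)c(OC)cc3O2)cc1`) gives 40%, the lower of the two numbers so far. Compound 2 (`COc1cc2c(cc1CC=C(C)C)/C(=N/O)C[C@@H](c1ccc(O)cc1)O2`) gives 93%, higher by a margin beyond the scatter. These two differ in more than one place, so the gap cannot be tied to any single group. Compound 3 (`COc1ccc([C@@H]2C/C(=N/OCc3cn(-c4ccc(NC(C)=O)cc4)nn3)c3cc(CC=C(C)C)c(OC)cc3O2)cc1`) keeps the core of compound 1 and changes one group: acetamido in place of cyano on an aromatic carbon. This puts acetamido in place of cyano on an aromatic carbon, para to a large group. Among the compounds with values here, no measured pair isolates this change, so the data give no direct size for it. The expectation in this assay is a slight rise at most, with no step beyond the scatter. The estimated step is a number 5 percentage points higher from compound 1 to compound 3 (within the scatter). For compound 3, the expected value is 45%, within a range from 25% to 65%.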

Compound 3, percent growth inhibition at one concentration: 0%
Compound 3: the middle estimate sits 45 percentage points above what was measured; measured number below the stated range.
By their numbers in this assay, from the lowest: compound 3; then compound 1; then compound 2.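

In this assay, going by these compounds alone, the change from 4-cyanophenyl to 4-acetamidophenyl gives the first comparison that differs in one place, and it reads a number 40 percentage points lower from compound 1 to compound 3 (beyond the scatter). The earlier compounds shown here could not show that this aromatic carbon, para to a large group, is sensitive to what it carries: with the rest of the core of compound 1 kept, compound 3 stands at 0% in this assay. Nothing measured here bears on why this replacement has such a large effect.

The compounds shown do not tell whether an amine, a carboxylic acid or a plain hydrogen at this carbon would sit nearer compound 1 or compound 3. They also leave open which of the several differences separates compound 2 from the other two compounds.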